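The source may hold more compounds than are shown below. What is called first, only, known or untested is meant among the compounds shown, and "the series" means these compounds.

Measured in an ADME assay on HEK293 cells (Homo sapiens) for cytotoxicity, read by resazurin assay, with a stated time of 72 h (on this read-out higher numbers stand for lower toxicity in this test and lower numbers for higher toxicity in this test), all three readings are limits:
- compound 1 `COc1cccc(CNC(=O)c2nc3ccc(F)c(OCCc4ccccc4)c3c(=O)[nH]2)c1` reads > 20000 nM as a limit
- compound 2 `CC(C)c1cccc(CNC(=O)c2nc3ccc(F)c(OCCc4ccc(C(=O)O)cc4)c3c(=O)[nH]2)c1` reads > 20000 nM as a limit
- compound 3 `CCc1cccc(C(C)NC(=O)c2nc3ccc(F)c(OCCc4ccc(C(=O)O)cc4)c3c(=O)[nH]2)c1` reads > 20000 nM as a limit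

Compound 2 has no number, only the limit > 20000 nM in this assay. Among the compounds with values here, the same holds across the set, with the limit of > 20000 nM in this assay, at which 3 of the 3 values shown sit, as the only reading so far. No ranking of the three compounds can be drawn from this.

Compound 4 `CCc1cccc(CN(C)C(=O)c2nc3ccc(F)c(OCCc4ccc(C(=O)O)cc4)c3c(=O)[nH]2)c1` is the next one to read, and it differs from compound 2 as follows: (3-ethylbenzyl)(methyl)amino in place of (3-isopropylbenzyl)amino on a carbonyl carbon. In words, this is (3-ethylbenzyl)(methyl)amino in place of (3-isopropylbenzyl)amino on a carbonyl carbon.

Within the data shown here, the one measured step that bears on this is a step that the two limits leave unreadable from compound 2 to compound 3, where 1-(3-ethylphenyl)ethyl replaces 3-isopropylbenzyl on an amide-type nitrogen. Its size cannot be read, as both ends are limits. That step therefore gives no size to carry over, but it shows no drop from the limit either.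

The expected step is a step that the limit leaves unreadable from compound 2 to compound 4, which means no change beyond the scatter is expected in this assay, in either direction. For compound 4 the estimate is 25000 nM, with an expected range of 15000 nM to 40000 nM, and a report as a limit once more is the likeliest outcome.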

Compound 4, half-maximal cytotoxic concentration: > 20000 nM
Compound 4: a limit, no number; the forecaster's own chance of this, stated with the estimate: 90%; the middle value lies beyond the limit too.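

In this assay compound 4 gives > 20000 nM, which is a limit and not a number. No new step can be read: the steps linking compound 4 with compound 2 and compound 3 join limits only, and their sizes stay unreadable. The compounds shown leave open whether any structural change among them alters the read-out, with every reading at one value: the limit of > 20000 nM in this assay, at which 4 of the 4 values shown sit.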